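Taking the Silyl Group off Compound 3

This account rests on a few compounds, and the source may have more. Where it says the series, first, only, none or still open, it means among the compounds named here.

In an ADME assay on ECV-304 cells (Homo sapiens) for cytotoxicity, read by MTT assay, with a stated time of 72 h (a higher number here means a weaker inhibitor, a lower number a stronger inhibitor), compound 3 (`COc1ccc(C2=C(c3cc(OC)c(OC)c(OC)c3)C(=O)C(O[SiH2]C(C)(C)C)C2)cc1OC(C)C`) gives > 100 ug/mL, which is a limit and not a number. Compound 1 (`C=CCOc1cc(C2=C(c3cc(OC)c(OC)c(OC)c3)C(=O)C(O)C2)ccc1OC`) gives > 100 ug/mL, also a limit. Compound 2 (`COc1ccc(C2=C(c3cc(OC)c(OC)c(OC)c3)C(=O)C(O)C2)cc1`) gives < 1 ug/mL, again a limit.

Compound 4 (`COc1ccc(C2=C(c3cc(OC)c(OC)c(OC)c3)C(=O)C(O)C2)cc1OC(C)C`) comes from compound 3 through one change, (a hydrogen atom in place of a group of 5 heavy atoms (4 carbon, 1 silicon; no ring), on an oxygen on a saturated carbon), on an oxygen on a saturated carbon. Within the data shown here, no measured step covers this change directly. Among the measured compounds shown here, the only measured step is an at least 100-fold lower number from compound 1 to compound 2 (2.00 log units; beyond the scatter), and it is a different change: hydrogen in place of allyloxy on an aromatic carbon. That large step rests on two limits, the limit of < 1 ug/mL in this assay, at which 1 of the 3 values shown sits, and (the limit of > 100 ug/mL in this assay, at which 2 of the 3 values shown sit).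

Compound 1 and compound 2 both carry the hydrogen on that oxygen, so it does not by itself settle where a compound falls in this assay. Compound 4 keeps the isopropoxy group of compound 3, and compound 2 has no such group. Its closest measured comparison is therefore compound 1, which sits at > 100 ug/mL.

A modest move toward a lower number is expected, with an at least 2.0-fold lower number from compound 3 to compound 4 (0.30 log units; that floor lies within the scatter) as the estimated step. For compound 4 the estimated value is 50 ug/mL, with an expected range of 5 ug/mL to 200 ug/mL.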

Compound 4, half-maximal inhibitory concentration: > 100 ug/mL
Compound 4: no number, only a limit (the forecaster's own chance of this, stated with the estimate: 45%); middle value at least 2.0-fold (0.30 log units) from the limit.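

With the hydrogen on the oxygen on a saturated carbon, compound 4 still stands at the same limit as compound 3 in this assay, so this change brings no measurable value, and the steps to compound 4 from compound 3 and from compound 1 cannot be read. Among these compounds, the one readable step is an at least 100-fold higher number from compound 2 to compound 4 (2.00 log units; beyond the scatter), with isopropoxy in place of hydrogen on an aromatic carbon, so the hydrogen on the oxygen on a saturated carbon does not alone place a compound at the low end. Of the compounds shown that carry this hydrogen, compound 1 and compound 4 have a group on that aromatic carbon and stay at the high limit, whereas compound 2 has only hydrogen there and falls at the low one: the limit of < 1 ug/mL in this assay, at which 1 of the 4 values shown sits.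

The limits leave open how far compound 1, compound 3 and compound 4 lie from one another in this assay, and whether removing the silyl group changes the number at all. Going by these compounds, it also remains open whether ethoxy or an amine in place of the isopropoxy on that aromatic carbon would give a value between the two limits.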